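Hydroxy to dimethylamino on the pendant aryl of compound 3

The compounds below may be only part of what the source reports. "The series", "measured", "known", "first", "only" and "open" are said of these compounds alone.

Three compounds share one core and differ only in the group on the pendant six-membered aromatic ring. Compound 1 `COc1cc(/C=C/C(=O)C2=C(/C=C/c3ccc(O)c(OC)c3)NC(=O)NC2c2ccccc2)ccc1O` carries hydrogen there and in a functional assay, with a stated time of 20 min, tested at 20 uM (a lower number here means a weaker effect, a higher number a stronger effect of the compound at the concentration tested), compound 1 gives 31%. Compound 2 `COc1cc(/C=C/C(=O)C2=C(/C=C/c3ccc(O)c(OC)c3)NC(=O)NC2c2ccc(C)cc2)ccc1O` carries methyl and in this assay compound 2 gives 36.3%. Compound 3 `COc1cc(/C=C/C(=O)C2=C(/C=C/c3ccc(O)c(OC)c3)NC(=O)NC2c2ccc(O)cc2)ccc1O` carries hydroxy and in this assay compound 3 gives 80.1%, the highest of the three, with both steps to it beyond the scatter. The steps: a number 5.3 percentage points higher from compound 1 to compound 2 (within the scatter), a number 49.1 percentage points higher from compound 1 to compound 3 (beyond the scatter), a number 43.8 percentage points higher from compound 2 to compound 3 (beyond the scatter).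

Compound 4 `COc1cc(/C=C/C(=O)C2=C(/C=C/c3ccc(O)c(OC)c3)NC(=O)NC2c2ccc(N(C)C)cc2)ccc1O` is the next step from compound 3: dimethylamino in place of hydroxy on an aromatic carbon. Among the compounds with values here, the steps that bear on it are those into compound 3, where putting hydroxy in place of hydrogen or of methyl raised the activity by a large margin in each case. The change into compound 4 takes the hydroxy away again, keeping one acceptor but no donor. A large fall is therefore expected in this assay, though the retained acceptor leaves the size uncertain; the estimated step is a number 35.1 percentage points lower from compound 3 to compound 4 (beyond the scatter). For compound 4 the expected value in this assay is 45%, within a range from 25% to 70%.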

Compound 4, a percentage reported as activity, at one concentration (the size of the read-out at that concentration, not a potency): 82.2%
Beside the measured number, compound 4's estimate is 37.2 percentage points below it; measured number above the stated range.
By their numbers in this assay, from the lowest: compounds 1 and 2 (each within the scatter of the next); then compounds 3 and 4 (each within the scatter of the next).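

Notes on the para position of the pendant aryl: in this assay the change from hydroxy to dimethylamino gives a number 2.1 percentage points higher from compound 3 to compound 4 (within the scatter), so the high read-out seen with hydroxy does not depend on a hydrogen-bond donor at this place, since dimethylamino has none and the acceptor count stays the same. The larger, three-atom group is also accommodated here without a visible loss, and it keeps the large separation from the two other groups, with a number 45.9 percentage points higher from compound 2 to compound 4 (beyond the scatter) for the change from methyl and a number 51.2 percentage points higher from compound 1 to compound 4 (beyond the scatter) for the change from hydrogen. Nothing at hand explains why hydroxy and dimethylamino read out alike here or why both stand apart from methyl and hydrogen.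

Methoxy, amino and a carboxylic acid at this place would test whether the high read-out follows a hydrogen-bond acceptor, an attached oxygen or nitrogen, or something else that these four compounds cannot separate. The read-out also comes from one concentration, so compound 3 and compound 4 may still differ in the size of their effect at other concentrations, which a full concentration series would show.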